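Ester oxygen substituent: cyclohexyl in place of pentan-3-yl

A few compounds are considered here, and "the series" means these few. Any claim that something is new, unique, unknown or untested is made for them only; others in the source may bear on it.

Measured so far:
compound 1 `COC(=O)C1=C(C)NC(=O)NC1c1cccs1`: 6%
compound 2 `CCC(CC)OC(=O)C1=C(C)NC(=O)NC1c1cccs1`: 13%

In an assay on membranes from CHO cells for displacement of a labelled ligand from adenosine receptor A1 (Homo sapiens), read by scintillation counting, with a stated time of 60 min, tested at 1 uM (a lower number here means less inhibition, a higher number more inhibition at the concentration tested (going by the name of the read-out)), compound 1 gives 6% and compound 2 gives 13%. Compound 2 stands alongside compound 1: the step of a number 7 percentage points higher from compound 1 to compound 2 (within the scatter) is within the scatter, so the two numbers do not separate. Compound 3 `CC1=C(C(=O)OC2CCCCC2)C(c2cccs2)NC(=O)N1` differs from compound 2 by cyclohexyl in place of pentan-3-yl on an oxygen next to a carbonyl group. Within the data shown here, the one measured step at this place, a number 7 percentage points higher from compound 1 to compound 2 (within the scatter), was within the scatter, so no step beyond the scatter is expected here either. For compound 3 the expected value is 15%, with a range from 3% to 30%. The expected step is a number 2 percentage points higher from compound 2 to compound 3 (within the scatter).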

Compound 3, a percentage reported as inhibition, at one concentration (the size of the read-out at that concentration, not a potency): 7%
For compound 3 the middle estimate is 8 percentage points above the measured one, and the stated range covers the measured number.
By their numbers in this assay, from the lowest: compounds 1, 3 and 2 (each within the scatter of the next).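

With cyclohexyl in place of pentan-3-yl on an oxygen next to a carbonyl group, this assay shows a number 6 percentage points lower from compound 2 to compound 3 (within the scatter), and with cyclohexyl in place of methyl at the same place it shows a number 1 percentage points higher from compound 1 to compound 3 (within the scatter). A six-membered carbon ring on this oxygen therefore does not separate from either open-chain group, leaving all three compounds within the scatter of one another at the concentration tested. Nothing measured on these compounds accounts for this reading.

From the compounds shown here alone, whether an amine or a carboxylic acid on this oxygen would separate from these values remains open. So does the effect of a longer chain or a phenyl group there.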